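The compounds below may be only part of what the source reports. "The series", "measured", "known", "first", "only" and "open" are said of these compounds alone.

Compounds measured so far:
compound 1, `CC(C)C[C@H]1C[C@@H](Cl)C[C@@H](C)O1`: > 100000 nM
compound 2, `CC(C)C[C@H]1C[C@@H](Cl)C[C@@H](c2ccccc2)O1`: 24000 nM

For the measured compounds named here, in a functional assay on SW1573 cells (Homo sapiens) for antiproliferative activity (a higher number here means a weaker inhibitor of growth, a lower number a stronger inhibitor of growth), compound 2 gives 24000 nM, the only number among the values shown. For compound 1 the result of > 100000 nM is a limit of the assay rather than a number (the limit of > 100000 nM in this assay, at which 1 of the 2 values shown sits). Going by the values given here, no step between these two compounds is given; their values show only that compound 2 falls inside the measured range while compound 1 does not.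

Compound 3, `CC(C)C[C@H]1C[C@@H](Cl)C[C@@H](c2ccc([N+](=O)[O-])cc2)O1`, is compound 2 with nitro in place of hydrogen on an aromatic carbon. Among the compounds with values here, no measured step offers a precedent for this change. A modest gain in growth inhibition is nevertheless expected, a 2.0-fold lower number from compound 2 to compound 3 (0.30 log units; within the scatter), a step of a size near the edge of the usual scatter rather than clearly beyond it. Compound 3 is therefore expected to give 12000 nM in this assay, with a range from 3000 nM to 40000 nM.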

Compound 3, concentration for 50% growth inhibition: 30000 nM
For compound 3 the middle estimate is 2.5-fold (0.40 log units) below the measured one; measured number inside the range.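

Nitro in place of hydrogen on an aromatic carbon, para to a large group, gives the only readable step among these compounds: in this assay it brings a 1.3-fold higher number from compound 2 to compound 3 (0.10 log units; within the scatter). Compound 2 and compound 3 therefore cannot be told apart in this assay, so at this position a nitro group, with its added heavy atoms and hydrogen-bond acceptors, leaves the growth inhibition within the usual scatter of a hydrogen. Nothing given here bears on why the step is so small.

From the compounds shown here alone, whether an amine, a carboxylic acid or a methoxy group on the same carbon would bring a step beyond the scatter remains open. Going by these compounds, it is also open whether nitro would give a similar result on another carbon of the aromatic ring.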